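A few compounds are considered here, and "the series" means these few. Any claim that something is new, unique, unknown or untested is made for them only; others in the source may bear on it.

Series notes. Compound 1 `CCOC(=O)N1CCC(=NNC(=O)c2ccc(C(F)(F)F)cc2)CC1` and compound 2 `CCOC(=O)N1CCC(=NNC(=O)c2ccc([N+](=O)[O-])cc2[N+](=O)[O-])CC1` share one core, while compound 3 `O=C(NN=C1CC(c2ccccc2)NC(c2ccccc2)C1)c1ccc(Cl)cc1` is built on another. In a toxicity assay on BJ cells (Homo sapiens) for cytotoxicity, read by MTT assay, with a stated time of 24 h (on this read-out lower numbers stand for stronger inhibition and higher numbers for weaker inhibition), compound 1 gives > 400000 nM, which is a limit of the assay and not a number. Compound 2 likewise reaches only the limit > 400000 nM in this assay. Compound 3 also stands at a limit in this assay, namely > 400000 nM, so no number is available for it, and the two other values shown are limits as well. All that fixes where compound 3 stands is the limit of > 400000 nM in this assay, at which 3 of the 3 values shown sit. Compound 4 `O=C(NN=C1CC(c2ccccc2)NC(c2ccccc2)C1)c1ccc(C(F)(F)F)cc1` keeps the core of compound 3 and differs from it by trifluoromethyl in place of chloro on an aromatic carbon. Among the compounds with values here, no step between two measured compounds covers this change. Because every measured value sits at the limit of > 400000 nM in this assay, at which 3 of the 3 values shown sit, no movement beyond the scatter is expected, and the step from compound 3 to compound 4 is estimated as a step that the limit leaves unreadable from compound 3 to compound 4. Compound 4 is therefore expected to give about 500000 nM in this assay, within 200000 nM to 2000000 nM, most likely reported again only as a limit.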

Compound 4, half-maximal inhibitory concentration: > 400000 nM
Compound 4 gave a limit, no number; the forecaster's own chance of this, stated with the estimate: 85%; the middle value lies beyond the limit too.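

No step can be read from compound 3 to compound 4 in this assay, and the same holds for the series as a whole, with every value only a limit: the limit of > 400000 nM in this assay, at which 4 of the 4 values shown sit.

The compounds shown leave open whether the core or the aromatic substituent changes this read-out at all.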